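Working notes: from 3-chlorophenyl to 4-fluorophenyl

The source may report more compounds than this note shows. Statements on the series, on what has been measured and on what is new or still open speak of the compounds shown alone.

Measured in a functional assay on SGC-7901 cells (Homo sapiens) for antiproliferative activity, read by MTT assay, with a stated time of 24 h; on this read-out higher numbers stand for weaker inhibition and lower numbers for stronger inhibition:
- compound 1 `Cc1cccc(NNC(=O)c2ccccc2NS(=O)(=O)c2cnc(O)nc2O)c1`: > 20000 nM (a limit of the assay, not a number)
- compound 2 `Cc1ccc(C(=O)NNC(=O)c2ccccc2NS(=O)(=O)c2cnc(O)nc2O)cc1`: 15500 nM
- compound 3 `O=C(NNC(=O)c1ccccc1NS(=O)(=O)c1cnc(O)nc1O)c1cccc(Cl)c1`: 1820 nM

Compound 3 has the lowest number of the three, and its steps to both other compounds lie beyond the scatter. Next in line is compound 4 `O=C(NNC(=O)c1ccccc1NS(=O)(=O)c1cnc(O)nc1O)c1ccc(F)cc1`, with 4-fluorophenyl in place of 3-chlorophenyl on a carbonyl carbon.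

The closest evidence is a modest step at this same place, an 8.5-fold lower number from compound 2 to compound 3 (0.93 log units; beyond the scatter). It replaced 4-methylphenyl with 3-chlorophenyl. The other two steps, an at least 1.2-fold lower number from compound 1 to compound 2 (0.11 log units; that floor lies within the scatter) and an at least 10-fold lower number from compound 1 to compound 3 (1.04 log units; beyond the scatter), change an amine nitrogen substituent and bear on this change less directly. Going by the values given here, no measured compound carries 4-fluorophenyl, so the size of the step remains uncertain.

In this assay, part of the gain seen in compound 3 is expected to be lost, giving a modest move toward a higher number. The estimated step is a 2.7-fold higher number from compound 3 to compound 4 (0.44 log units; beyond the scatter). The expected value for compound 4 is 5000 nM, with an estimated range of 1500 nM to 18000 nM.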

Compound 4, half-maximal inhibitory concentration: > 20000 nM
Compound 4 gave a limit, no number; the forecaster's own chance of this, stated with the estimate: 10%; at least 4.0-fold (0.60 log units) between middle value and limit.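

Compound 4 gives > 20000 nM, a limit of the assay and not a number. In this assay, 4-fluorophenyl on this carbonyl carbon gives an at least 10-fold higher number from compound 3 to compound 4 (1.04 log units; beyond the scatter), and fluoro in place of methyl gives an at least 1.2-fold higher number from compound 2 to compound 4 (0.11 log units; that floor lies within the scatter), so no order can be stated for compound 2 and compound 4, and of the three groups shown at this place only 3-chlorophenyl stands clearly apart. The step from compound 1 to compound 4 cannot be read, with both values at the same limit: the limit of > 20000 nM in this assay, at which 2 of the 4 values shown sit.

Open, from the compounds shown here alone, is what 4-chlorophenyl or 3-fluorophenyl would give on this carbonyl carbon, which would separate the two changes made at once in going from 3-chlorophenyl to 4-fluorophenyl. Also open, going by these compounds, is how a group other than substituted phenyl, such as cyclohexyl, would read at this place.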